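Trimming a Pyridylethyl Amide Down to Dimethylamide

The source may hold more compounds than are shown below. What is called first, only, known or untested is meant among the compounds shown, and "the series" means these compounds.

Measured compounds:
Compound 1 `CC(NC(=O)C1CCN(C(=O)c2cc3ccccc3n2Cc2ccc(Cl)cc2)CC1)c1ccncc1`: 90100 nM
Compound 2 `CN1CCN(C(=O)C2CCN(C(=O)c3cc4ccccc4n3Cc3ccc(Cl)cc3)CC2)CC1`: 75600 nM
Compound 3 `O=C(NCCCc1ccncc1)C1CCN(C(=O)c2cc3ccccc3n2Cc2ccc(Cl)cc2)CC1`: 71500 nM

All three compounds were tested in an ADME assay on BE(2)-C cells (Homo sapiens) for cytotoxicity, read by MTT assay, with a stated time of 20 h; on this read-out higher numbers stand for lower toxicity in this test and lower numbers for higher toxicity in this test. Compound 1 gives the highest of the three numbers, but its margins to the others are small: a 1.2-fold lower number from compound 1 to compound 2 (0.08 log units; within the scatter) and a 1.3-fold lower number from compound 1 to compound 3 (0.10 log units; within the scatter), and between the other two a 1.1-fold lower number from compound 2 to compound 3 (0.02 log units; within the scatter). On these numbers the three compounds cannot be told apart.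

Compound 4 `CN(C)C(=O)C1CCN(C(=O)c2cc3ccccc3n2Cc2ccc(Cl)cc2)CC1` has not yet been measured. Compared with compound 1 it carries a much smaller group at the amide end of the shared core: dimethylamino in place of (1-(pyridin-4-yl)ethyl)amino on a carbonyl carbon. The step from compound 1 to compound 2 is the closest guide, as it also replaces the amide group on the carbonyl carbon with a group lacking the pyridine ring, and it stayed within the scatter; the step from compound 1 to compound 3 likewise stayed within the scatter. Among the compounds with values here, no change at this position so far has moved the read-out, so for compound 4 the expected step is a 1.1-fold lower number from compound 1 to compound 4 (0.05 log units; within the scatter), in no particular direction. The estimate for compound 4 is 80000 nM, with a likely range from 40000 nM to 160000 nM.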

Compound 4, half-maximal cytotoxic concentration in the BE(2)-C assay: > 100000 nM
Compound 4 gave a limit, no number; the forecaster's own chance of this, stated with the estimate: 20%; middle value at least 1.2-fold (0.09 log units) from the limit.
By their numbers in the BE(2)-C assay, from the lowest: compounds 3, 2 and 1 (each within the scatter of the next). At a limit, above all of these: compound 4.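

In the BE(2)-C assay compound 4 gives > 100000 nM, which is a limit and not a number: the limit of > 100000 nM in the BE(2)-C assay, at which 1 of the 4 values shown sits. In the BE(2)-C assay the steps can be read only as floors, an at least 1.1-fold higher number from compound 1 to compound 4 (0.04 log units; that floor lies within the scatter), an at least 1.3-fold higher number from compound 3 to compound 4 (0.14 log units; that floor lies within the scatter) and an at least 1.3-fold higher number from compound 2 to compound 4 (0.12 log units; that floor lies within the scatter), so this carbonyl carbon can carry dimethylamino, with 3 heavy atoms and no ring, with no sign of a lower number than the larger groups give. In a physicochemical assay for solubility, measured as kinetic solubility (a higher number here means a more soluble compound, a lower number a less soluble compound), compound 1 gives 31000 nM and compound 4 gives 62000 nM. In the physicochemical assay the same change is a 2.0-fold higher number from compound 1 to compound 4 (0.30 log units; within the scatter), so that read-out does not separate the two compounds either.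

As far as these compounds go, with only floors to go on, it remains open whether compound 4 truly differs from the other three compounds in the BE(2)-C assay. Also open, from the compounds shown here alone, is what a morpholin-4-yl group or a longer alkyl chain in place of dimethylamino would do to either read-out.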